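Swapping acetyl for dimethylamino on a pyrazole-based cytotoxic series

A few compounds are considered here, and "the series" means these few. Any claim that something is new, unique, unknown or untested is made for them only; others in the source may bear on it.

Of the compounds shown here, three of one family have been tested in a functional assay on HOP-92 cells (Homo sapiens) for cytotoxicity, read by sulforhodamine B assay, with a stated time of 48 h, tested at 100 nM; on this read-out higher numbers stand for a weaker effect at the one concentration tested and lower numbers for a stronger effect. Compound 1 `COc1cc(C)cc(-c2c(-c3ccnc(-c4ccc(C(C)=O)cc4)c3)cnn2CC#N)c1` gives 61%. Compound 2 `Cc1cc(O)cc(-c2nn(CC#N)cc2-c2ccnc(-c3ccc(Oc4ccccc4)cc3)c2)c1` gives 70%, a number within the scatter of that of compound 1, so the two cannot be told apart. Compound 3 `COc1cc(C)cc(-c2nn(CC#N)cc2-c2ccnc(-c3ccc(N(C)C)cc3)c2)c1` gives 35%, well below the number of compound 1, which marks a clearly stronger effect at the single concentration used. Compound 1 therefore stands second highest of the three numbers, close to compound 2 and far from compound 3.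

Compound 4 `COc1cc(C)cc(-c2c(-c3ccnc(-c4ccc(N(C)C)cc4)c3)cnn2CC#N)c1` has not yet been measured. It differs from compound 1 in one place: dimethylamino in place of acetyl on an aromatic carbon. Among the compounds with values here, compound 3 also carries a dimethylamino group, although it differs from compound 1 elsewhere as well, so no single-change step toward it is available. Since compound 3 gives 35%, a step from compound 1 downward, beyond the scatter, is expected, meaning a stronger effect: the estimated step is a number 16 percentage points lower from compound 1 to compound 4 (beyond the scatter). The number for compound 4 is expected to be about 45%, with a likely range from 25% to 70%.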

Compound 4, a percentage reported as activity, at one concentration (the size of the read-out at that concentration, not a potency): -3%
Compound 4: the middle estimate sits 48 percentage points above what was measured; measured number outside the range, below it.
By their numbers in this assay, from the lowest: compound 4; then compound 3; then compounds 1 and 2 (each within the scatter of the next).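

Within the data shown here, replacing acetyl with dimethylamino on the aromatic carbon para to a large group gives a number 64 percentage points lower from compound 1 to compound 4 (beyond the scatter) in this assay, and this is the first comparison where only one place changes. The whole shift can therefore be assigned to the move from 4-acetylphenyl to 4-(dimethylamino)phenyl, and this position clearly matters for the read-out. The two groups match in their count of heavy atoms and of hydrogen-bond acceptors, so those counts do not separate them; they differ in nitrogen against oxygen and in the double bond that leaves with the acetyl, but nothing measured here explains why the number moves so far.

Going by these compounds, with only these two groups compared at this position, it remains open whether a similar shift would come with a simple primary amine, a methoxy group or a morpholine ring. On these data alone, it is also open whether the same change would matter as much on another cell line or at other concentrations, since one reading at a single concentration is no measure of potency.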